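Bromo for Methoxy on a Chromone Amide Series

This account rests on a few compounds, and the source may have more. Where it says the series, first, only, none or still open, it means among the compounds named here.

Measured compounds:
Compound 1, `COc1ccc2occ(C(=O)NC3CCN(Cc4ccccc4)CC3)c(=O)c2c1`, gives 7.5%.
Compound 2, `O=C(NC1CCN(Cc2ccccc2)CC1)c1coc2ccc(Br)cc2c1=O`, gives 35.5%.
Compound 3, `COc1ccc2c(=O)c(C(=O)NCCC3CCN(Cc4ccccc4)CC3)coc2c1`, gives 32.4%.

All three were tested in an assay on isolated protein for inhibition of Amine oxidase [flavin-containing] A (Homo sapiens), read by fluorescence and Amplex Red, with stated times of 15 min and 20 min, tested at 100 uM; a lower number here means less inhibition, a higher number more inhibition at the concentration tested (going by the name of the read-out). Among the compounds with values here, compound 1 sits lowest, and the single change from compound 1 to compound 2, (bromo in place of methoxy on an aromatic carbon), brings a number 28 percentage points higher from compound 1 to compound 2 (beyond the scatter). Compound 3 carries the same methoxy group as compound 1 but differs from it in more than one place; the difference between the two cores is not broken down here. Compound 3 stands close to compound 2, and the two values lie within the scatter of each other, so no order between them can be read.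

Compound 4, `O=C(NCCC1CCN(Cc2ccccc2)CC1)c1coc2cc(Br)ccc2c1=O`, has not yet been measured in this assay. Within the data shown here, it differs from compound 3 by bromo in place of methoxy on an aromatic carbon, and this is the same change as the one from compound 1 to compound 2, at the same place on the ring. On that basis the step is expected to run in the same direction, though compound 3 already starts from a higher number than compound 1, so the gain is expected to be somewhat smaller: compound 4 is expected to rise by a number 19.6 percentage points higher from compound 3 to compound 4 (beyond the scatter). The estimate for compound 4 is 52%, with a range from 35% to 70%.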

Compound 4, a percentage reported as inhibition, at one concentration (the size of the read-out at that concentration, not a potency): 30.3%
The estimate for compound 4 lay 21.7 percentage points above the measured number; measured number below the stated range.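

On the core of compound 3, bromo in place of methoxy on an aromatic carbon gives a number 2.1 percentage points lower from compound 3 to compound 4 (within the scatter) in this assay, so the change has no readable effect on this core. The change therefore does not carry over with the size it had on the core of compound 1, and the two steps are clearly different: the same change on two cores in this assay, a number 28 percentage points higher (beyond the scatter) from compound 1 to compound 2 and a number 2.1 percentage points lower (within the scatter) from compound 3 to compound 4, 30.1 percentage points apart, beyond the scatter of two such steps

Within the data shown here, this shows that, within this small series, the result of the swap depends on the core that carries it, but it rests on only two pairs of compounds, each read at one concentration. The core of compound 1 and the core of compound 3 differ in more than one place, so the data do not show which of those differences matters, nor do they give any reason for the contrast.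

The compounds shown carry only methoxy or bromo at this aromatic carbon, so it remains open whether chloro, fluoro or a nitrile would follow the step seen on one core, the other or neither. From the compounds shown here alone, it also remains open whether a longer chain on the amide would bring back a gain from bromo.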